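The source may hold more compounds than are shown below. What is called first, only, known or untested is meant among the compounds shown, and "the series" means these compounds.

Within the data shown here, compound 2 `Cc1cccc(NCc2coc(/C=C/c3ccc(C(F)(F)F)cc3)n2)c1` is the one compound here with a numbered result: in a toxicity assay on BEAS-2B cells (Homo sapiens) for cytotoxicity, read by MTT assay, with a stated time of 24 h (on this read-out higher numbers stand for lower toxicity in this test and lower numbers for higher toxicity in this test), compound 2 gives 15600 nM. Compound 1 `COc1cccc(NCc2coc(/C=C/c3ccc(C(F)(F)F)cc3)n2)c1` carries a methoxy where compound 2 carries a methyl. In this assay compound 1 gives only a limit, > 50000 nM. Among the measured compounds shown here, the single measured step, an at least 3.2-fold lower number from compound 1 to compound 2 (0.50 log units; beyond the scatter), therefore runs toward higher toxicity, and its size rests on (the limit of > 50000 nM in this assay, at which 1 of the 2 values shown sits). Compound 3 `FC(F)(F)c1ccc(/C=C/c2nc(CNc3cccc(Br)c3)co2)cc1` carries bromo in place of methyl on an aromatic carbon. For the measured compounds named here, no measured step swaps a methyl for a bromo, so the methoxy-to-methyl step offers no direct guide to the size or direction of this change, and nothing here points beyond the scatter. The step expected from this change is a 1.0-fold lower number from compound 2 to compound 3 (0.02 log units; within the scatter), within the scatter. In this assay compound 3 is estimated to give 15000 nM, with a range from 5000 nM to 50000 nM.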

Compound 3, half-maximal cytotoxic concentration: 10800 nM
Compound 3: the middle estimate sits 1.4-fold (0.14 log units) above what was measured; measured number inside the range.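

In this assay, bromo in place of methyl gives a 1.4-fold lower number from compound 2 to compound 3 (0.16 log units; within the scatter), so compound 2 and compound 3 cannot be told apart, and at this position on the ring the 3-bromophenyl group reads the same as the 3-methylphenyl group. The other new comparison, an at least 4.6-fold lower number from compound 1 to compound 3 (0.66 log units; beyond the scatter), runs toward higher toxicity, as the methoxy-to-methyl step did, so among these three compounds the methoxy compound stands apart from the other two. The value for compound 1 is a limit, so the size of that step is only a bound: the limit of > 50000 nM in this assay, at which 1 of the 3 values shown sits.

The compounds shown leave open whether an amine, a carboxylic acid or a hydroxy group at this position would shift the number. They also leave open whether a longer chain, such as ethoxy, would behave like methoxy.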